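A Pyridin-4-yl Ketone in Place of a Methyl Ketone

The compounds below may be only part of what the source reports. "The series", "measured", "known", "first", "only" and "open" are said of these compounds alone.

compound 1, `CC(=O)c1sc(NC(C)C)c(C#N)c1N`: > 5000 nM
compound 2, `CC(C)Nc1sc(C(=O)c2cccc(C#N)c2)c(N)c1C#N`: > 5000 nM

Of the compounds shown here, two on a shared core have been tested in an assay for inhibition of Maternal embryonic leucine zipper kinase (Homo sapiens), read by ADP-Glo, with a stated time of 0.5 h; a higher number here means a weaker inhibitor, a lower number a stronger inhibitor. Compound 1 gives > 5000 nM, which is a limit of the assay and not a number. Compound 2 gives > 5000 nM, likewise a limit. Within the data shown here, both values sit at the limit of > 5000 nM in this assay, at which 2 of the 2 values shown sit, so compound 1 cannot be placed above or below compound 2, and no measured step between two numbers exists here.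

Compound 3, `CC(C)Nc1sc(C(=O)c2ccncc2)c(N)c1C#N`, has not yet been measured in this assay. It differs from compound 1 by pyridin-4-yl in place of methyl on a carbonyl carbon. Compound 2 also bears an aromatic ring on the carbonyl carbon and gives > 5000 nM, a limit, so nothing measured points toward a gain. The step expected in this assay is a step that the limit leaves unreadable from compound 1 to compound 3, which is none beyond the scatter. Compound 3 is expected to give 6000 nM, in a range from 1500 nM to 30000 nM, with a good chance that only a limit is reported again.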

Compound 3, half-maximal inhibitory concentration: > 5000 nM
Compound 3 gave a limit, no number; the forecaster's own chance of this, stated with the estimate: 70%; the middle value does not contradict the limit.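

In this assay, among these compounds, compound 3 gives only a limit, as do compound 1 and compound 2, so no step between compound 1 and compound 3 can be read: the limit of > 5000 nM in this assay, at which 3 of the 3 values shown sit. The compounds shown leave open whether any group on the carbonyl carbon gives a measurable value.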